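This account rests on a few compounds, and the source may have more. Where it says the series, first, only, none or still open, it means among the compounds named here.

Working notes on the series. In a functional assay on A-431 cells (Homo sapiens) for cytotoxicity (on this read-out higher numbers stand for an effect only at larger amounts of compound and lower numbers for an effect already at smaller amounts), compound 1 (`CCc1ccc(/C=C/C(O)=C2/C(=O)C(C)=C(OC)C(C)(C)C2=O)cc1`) gives 12 ug/mL and compound 2 (`CCC1=C(OC)C(CC)(CC)C(=O)C(C(=O)/C=C/c2ccccc2)=C1O`) gives 5.4 ug/mL as the lower of the two numbers, beyond the scatter. These two differ in more than one place, so no single change can be read from them. Compound 3 (`CCC1=C(OC)C(CC)(CC)C(=O)C(C(=O)/C=C/c2ccc(CC)cc2)=C1O`) follows from compound 2 through ethyl in place of hydrogen on an aromatic carbon on the aromatic ring, phenyl to 4-ethylphenyl. Among the compounds with values here, no measured pair isolates this change, and no step beyond the scatter is expected in this assay. The expected change is a 1.1-fold higher number from compound 2 to compound 3 (0.05 log units; within the scatter) in this read-out. Compound 3 is estimated at 6 ug/mL, with an expected range of 2.5 ug/mL to 14 ug/mL.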

Compound 3, concentration for half-maximal effect: 9.8 ug/mL
Estimate against measurement, compound 3: 1.6-fold (0.21 log units) below; measured number inside the range.
By their numbers in this assay, from the lowest: compounds 2, 3 and 1 (each within the scatter of the next, the first and the last beyond it).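

In this assay the series now has its first step that differs in one place: ethyl in place of hydrogen on an aromatic carbon, para to a large group, gives a 1.8-fold higher number from compound 2 to compound 3 (0.26 log units; within the scatter) and so stays within the scatter. This position therefore takes ethyl on the core of compound 2 without a step beyond the scatter. Nothing available bears on a cause for this step.

From the compounds shown here alone, whether a longer chain, an amine or a carboxylic acid at this position would give a step beyond the scatter remains open. Also open, going by these compounds, is how hydrogen and ethyl compare here on the core of compound 1.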